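Shrinking the Ring on Two Pyridine Cores

The source may report more compounds than this note shows. Statements on the series, on what has been measured and on what is new or still open speak of the compounds shown alone.

Compound 1, `Cc1cccc(/C(N)=N/NC(=S)N2CCCCC2)n1`: 85.7%
Compound 2, `Cc1cccc(/C(N)=N/NC(=S)N2CCCC2)n1`: 66.3%
Compound 3, `Cc1ccnc(/C(N)=N/NC(=S)N2CCCCC2)c1`: 85.6%

Of the compounds shown here, three have been measured in a functional assay on A-375 cells (Homo sapiens) for cytotoxicity, read by MTT assay, with a stated time of 72 h, tested at 100 uM; a lower number here means less inhibition of growth, a higher number more inhibition of growth at the concentration tested. Compound 1 and compound 3 share the same atoms joined differently; the difference between the two cores is not broken down here. In this assay compound 1 gives 85.7% and compound 3 gives 85.6%, two values within the scatter of each other. The change pyrrolidin-1-yl in place of piperidin-1-yl on a thiocarbonyl carbon gave a number 19.4 percentage points lower from compound 1 to compound 2 (beyond the scatter). Compound 4, `Cc1ccnc(/C(N)=N/NC(=S)N2CCCC2)c1`, has not yet been measured; it carries the same change, (pyrrolidin-1-yl in place of piperidin-1-yl on a thiocarbonyl carbon), on the core of compound 3. Because compound 3 sits at 85.6% and the step from compound 1 to compound 2 was a number 19.4 percentage points lower from compound 1 to compound 2 (beyond the scatter), a step of similar size is expected, a number 18.6 percentage points lower from compound 3 to compound 4 (beyond the scatter). Compound 4 is therefore estimated at 67%, between 52% and 80%.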

Compound 4, percent growth inhibition at one concentration: 88.8%
For compound 4 the middle estimate is 21.8 percentage points below the measured one; measured number outside the range, above it.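

In this assay, pyrrolidin-1-yl in place of piperidin-1-yl gave a number 3.2 percentage points higher from compound 3 to compound 4 (within the scatter). The change therefore did not carry over between these two cores, and its outcome here depended on the core it was made on: the same change on two cores in this assay, a number 19.4 percentage points lower (beyond the scatter) from compound 1 to compound 2 and a number 3.2 percentage points higher (within the scatter) from compound 3 to compound 4, 22.6 percentage points apart, beyond the scatter of two such steps

Going by these compounds alone, this comparison rests on only two pairs of compounds, each tested at one concentration, and it does not show which difference between the cores is responsible.

The compounds shown leave open how either core would respond to other groups on the thiocarbonyl carbon, such as morpholin-4-yl or an open-chain dimethylamino group. They also leave open whether the difference between the cores would persist with those groups.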